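The compounds below may be only part of what the source reports. "The series", "measured", "known", "first", "only" and "open" are said of these compounds alone.

In a functional assay on MCF-10A cells (Homo sapiens) for antiproliferative activity, with a stated time of 48 h (on this read-out higher numbers stand for an effect only at larger amounts of compound and lower numbers for an effect already at smaller amounts), compound 1 (`COc1ccc2nc(C)cc(NCc3cccc(OC(F)F)c3)c2c1`) gives 10300 nM and compound 2 (`COc1ccc2nc(C)cc(NCc3cccc(N(C)C)c3)c2c1`) gives 14000 nM, so the two stand within the scatter of each other. Compound 3 (`COc1ccc2nc(C)cc(NCc3cccc(CO)c3)c2c1`) carries hydroxymethyl in place of dimethylamino on an aromatic carbon. Going by the values given here, the only measured step that bears on this, a 1.4-fold higher number from compound 1 to compound 2 (0.13 log units; within the scatter), is another exchange on an aromatic carbon and lies within the scatter, so it gives no direction and no step beyond the scatter is expected. The expected change is a 1.2-fold lower number from compound 2 to compound 3 (0.07 log units; within the scatter). The estimate for compound 3 is 12000 nM, with an expected range of 5000 nM to 30000 nM.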

Compound 3, half-maximal effective concentration: 17100 nM
Beside the measured number, compound 3's estimate is 1.4-fold (0.15 log units) below it; measured number inside the range.
By their numbers in this assay, from the lowest: compounds 1, 2 and 3 (each within the scatter of the next).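

In this assay the third group at this place, on an aromatic carbon meta to a large group, again leaves the number within the scatter: a 1.2-fold higher number from compound 2 to compound 3 (0.09 log units; within the scatter) and a 1.7-fold higher number from compound 1 to compound 3 (0.22 log units; within the scatter). Hydroxymethyl brings a hydrogen-bond donor where dimethylamino has none, and this exchange gives no direction either. No supporting evidence bears on this result. The compounds shown leave open whether a carboxylic acid, a primary amine or a longer chain at this place would give a step beyond the scatter. They also leave open whether any exchange elsewhere on the shared core would do so.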